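Bromo added beside fluoro on the aryl oxime amidine

The source may hold more compounds than are shown below. What is called first, only, known or untested is meant among the compounds shown, and "the series" means these compounds.

Within the data shown here, in an assay on isolated protein for inhibition of Tryptophan 2,3-dioxygenase (Homo sapiens), read by spectrophotometry, with a stated time of 1 h (a lower number here means a stronger inhibitor, a higher number a weaker inhibitor), compound 2 `O=[N+]([O-])c1ccc(N/C(=N\O)c2ccc(F)cc2)c2nonc12` gives 21000 nM, the highest of the two numbers so far; compound 1 `O=[N+]([O-])c1ccc(N/C(=N\O)c2cccc(Br)c2)c2nonc12` gives 20000 nM, within the scatter of compound 2. Among the measured compounds shown here, the single measured step, a 1.1-fold higher number from compound 1 to compound 2 (0.02 log units; within the scatter), shows that exchanging one halogenated aryl for another left the number essentially unchanged. Compound 3 `O=[N+]([O-])c1ccc(N/C(=N\O)c2ccc(F)c(Br)c2)c2nonc12` carries both halogens: bromo in place of hydrogen on an aromatic carbon. For the measured compounds named here, because the only comparable step a 1.1-fold higher number from compound 1 to compound 2 (0.02 log units; within the scatter) lies within the scatter, no step beyond the scatter is expected in this assay, with a 1.2-fold lower number from compound 2 to compound 3 (0.07 log units; within the scatter). Compound 3 is therefore expected to give 18000 nM, ranging from 8000 nM to 40000 nM.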

Compound 3, half-maximal inhibitory concentration: 47000 nM
Compound 3: the middle estimate sits 2.6-fold (0.42 log units) below what was measured; measured number above the stated range.
By their numbers in this assay, from the lowest: compounds 1 and 2 (each within the scatter of the next); then compound 3.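

In this assay the two halogens together behave differently from either one alone: bromo ortho to a fluoro group gives a 2.2-fold higher number from compound 2 to compound 3 (0.35 log units; beyond the scatter) and is matched by fluoro added to the bromo aryl, which gives a 2.4-fold higher number from compound 1 to compound 3 (0.37 log units; beyond the scatter) as the second step. Both steps point to weaker inhibition, whereas exchanging one halogen for the other left the number within the scatter. Nothing on hand bears on the origin of this shift.

From the compounds shown here alone, whether an amine or a carboxylic acid on the same aromatic carbon would keep or reverse the rise stays open. So does whether chloro in place of bromo would follow it.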